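Dropping the methoxy group from compound 1

The source may report more compounds than this note shows. Statements on the series, on what has been measured and on what is new or still open speak of the compounds shown alone.

The study measured three compounds in a functional assay on MCF7 cells (Homo sapiens) for cytotoxicity, read by MTT assay, with a stated time of 72 h; a lower number here means a stronger inhibitor of growth, a higher number a weaker inhibitor of growth. Compound 1 `COc1ccc(CNc2nc(SC)nc3ncccc23)cc1` gives 48100 nM, the highest of the three numbers. Among the measured compounds shown here, compound 2 `CCCCC[Se]c1nc(NCc2ccccc2)c2ccccc2n1` gives 50 nM, and compound 3 `Nc1nc([SeH])nc2ccccc12` gives 150 nM; both lie far below compound 1, beyond the scatter, but neither differs from compound 1 in only one place, so their values show only that compound 1 is the weakest inhibitor of growth among the three. Compound 4 `CSc1nc(NCc2ccccc2)c2cccnc2n1` has not yet been measured. It differs from compound 1 by hydrogen in place of methoxy on an aromatic carbon. For the measured compounds named here, no single-change step between measured compounds informs this move, so in this assay the expected change is a 1.2-fold lower number from compound 1 to compound 4 (0.08 log units; within the scatter), within the scatter. Compound 4 is estimated at 40000 nM, between 10000 nM and 150000 nM.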

Compound 4, concentration for 50% growth inhibition: 39400 nM
Estimate against measurement, compound 4: 1.0-fold (0.01 log units) above; the range from low to high includes it.
By their numbers in this assay, from the lowest: compound 2; then compound 3; then compounds 4 and 1 (each within the scatter of the next).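

In this assay the swap of methoxy for hydrogen on the aromatic carbon para to a large group gives a 1.2-fold lower number from compound 1 to compound 4 (0.09 log units; within the scatter) and stays within the scatter. Among the compounds shown here, this is the first direct reading at this position, and it shows that the methoxy group can go without a change that can be told from scatter. Nothing shown accounts for this result.

From the compounds shown here alone, whether an amine or a carboxylic acid on this carbon would also leave the number within the scatter stays open. So does whether a longer chain such as butoxy would.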